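A few compounds are considered here, and "the series" means these few. Any claim that something is new, unique, unknown or untested is made for them only; others in the source may bear on it.

The series shares one core, seen in compound 1 `CN1CCN(c2ccc(Nc3nc(-c4cccc(NC(=O)c5ccc(C(F)(F)F)cc5)c4)sc3C(N)=O)cc2)CC1`, compound 2 `CN1CCN(c2ccc(Nc3nc(-c4cccc(NC(=O)c5ccc(Cl)cc5)c4)sc3C(N)=O)cc2)CC1` and compound 3 `CN1CCN(c2ccc(Nc3nc(-c4cccc(NC(=O)c5ccc(F)c(Cl)c5)c4)sc3C(N)=O)cc2)CC1`, and varies only the group on the carbonyl carbon of the amide. In a functional assay on Ramos cells (Homo sapiens) for antiproliferative activity, read by CCK-8 assay, with a stated time of 72 h, tested at 40 uM (on this read-out higher numbers stand for more inhibition at the one concentration tested (going by the name of the read-out) and lower numbers for less inhibition), compound 1 gives 97.8%, compound 2 gives 99% and compound 3 gives 97.5%. Compound 3 stands lowest of the three numbers, but its gaps to compound 1 and to compound 2 both fall within the scatter. The three measured steps, a number 1.2 percentage points higher from compound 1 to compound 2 (within the scatter), a number 0.3 percentage points lower from compound 1 to compound 3 (within the scatter) and a number 1.5 percentage points lower from compound 2 to compound 3 (within the scatter), all exchange one phenyl on the carbonyl carbon for another phenyl and all stay within the scatter.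

Compound 4 `CN1CCN(c2ccc(Nc3nc(-c4cccc(NC(=O)[C@H]5CC[C@H](C)CC5)c4)sc3C(N)=O)cc2)CC1` alters this position in a different way: 4-methylcyclohexyl in place of 3-chloro-4-fluorophenyl on a carbonyl carbon. Among the measured compounds shown here, no measured step covers the exchange of an aromatic ring for a non-aromatic one; the measured steps show only that the pattern on the phenyl leaves this read-out flat. Since the three measured compounds sit near the top of the scale, compound 4 is expected to stay high, with a step of a number 7.5 percentage points lower from compound 3 to compound 4 (within the scatter) expected and a wide allowance for the untested kind of change. The estimate for compound 4 in this assay is 90%, with a range from 70% to 100%.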

Compound 4, a percentage reported as inhibition, at one concentration (the size of the read-out at that concentration, not a potency): 55.1%
Estimate against measurement, compound 4: 34.9 percentage points above; the measured number lies below the stated range.
By their numbers in this assay, from the lowest: compound 4; then compounds 3, 1 and 2 (each within the scatter of the next).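

The position on the carbonyl carbon is not indifferent after all: this assay shows a number 42.4 percentage points lower from compound 3 to compound 4 (beyond the scatter) and a number 43.9 percentage points lower from compound 2 to compound 4 (beyond the scatter) and a number 42.7 percentage points lower from compound 1 to compound 4 (beyond the scatter) when 4-methylcyclohexyl enters. The flat read-out therefore holds only among the phenyl groups of compounds 1, 2 and 3, and the exchange of the six-membered aromatic ring for a non-aromatic one separates compound 4 from all three, with hydrogen-bond donor and acceptor counts and net charge unchanged in the exchanged group. Nothing available accounts for the size of this loss.

Compound 4 is the only non-aromatic ring shown, so it remains open whether the loss follows from the ring type or from this particular methyl-bearing ring with its two defined stereocentres. An unsubstituted cyclohexyl, a piperidine or a short alkyl chain on the carbonyl carbon would separate these readings.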